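This account rests on a few compounds, and the source may have more. Where it says the series, first, only, none or still open, it means among the compounds named here.

Measured in a physicochemical assay for solubility, measured as kinetic solubility; on this read-out lower numbers stand for lower solubility and higher numbers for higher solubility:

Compound 1 `O=C(CCCN1CCCCCC1)Nc1nnc(-c2ccc(F)cc2)s1`: > 91 ug/mL
Compound 2 `O=C(CCCN1CCCCCC1)Nc1cnc(-c2ccc(F)cc2F)s1`: > 97 ug/mL
Compound 3 `O=C(CCCN1CCCCC1)Nc1cnc(-c2ccc(F)cc2)s1`: > 94 ug/mL

For the measured compounds named here, all three results are limits of the assay, not numbers, so they set no order among the compounds. Compound 2 stands at a limit, > 97 ug/mL. Compound 4 `O=C(CCCN1CCCCCC1)Nc1cnc(-c2ccc(F)c(F)c2)s1` differs from it only in the fluorine pattern, with 3,4-difluorophenyl in place of 2,4-difluorophenyl on an aromatic carbon. Going by the values given here, no measured step between two compounds is available to guide this change in this assay. The expected step, an at least 1.0-fold lower number from compound 2 to compound 4 (0.00 log units; that floor lies within the scatter), is none beyond the scatter, with no direction expected. Compound 4 is estimated at 95 ug/mL, with an expected range of 55 ug/mL to 105 ug/mL.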

Compound 4, solubility: > 94 ug/mL
Compound 4 was reported as a limit; the forecaster's own chance of this, stated with the estimate: 75%; the middle value is on the limit's open side.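

Compound 2 and compound 4 both stand as limits in this assay, not numbers, so no step can be read between them. The compounds shown leave open where their true readings lie, and whether 3,4-difluorophenyl in place of 2,4-difluorophenyl shifts the read-out at all.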